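This account rests on a few compounds, and the source may have more. Where it says the series, first, only, none or still open, it means among the compounds named here.

Of the compounds shown here, three have been measured in a functional assay on HL-60 cells (Homo sapiens) for cytotoxicity, read by luminescence and CellTiter-Glo, with a stated time of 3 days; on this read-out higher numbers stand for weaker inhibition and lower numbers for stronger inhibition. Compound 1 `O=C(Nc1ccc(Cl)c(Br)c1)c1cc(Cl)ccc1O` gives 780 nM, compound 2 `O=C(Nc1cc(C(F)(F)F)cc(C(F)(F)F)c1)c1ccc(Cl)cc1O` gives 200 nM, and compound 3 `O=C(Nc1cc(C(F)(F)F)cc(C(F)(F)F)c1)c1cc(Br)c(-c2ccccc2)cc1O` gives 430 nM. Compound 2 thus stands lowest of the three numbers; compound 3 is nearest to it and lies beyond the scatter, while compound 1 is furthest and also lies beyond the scatter. Compound 4 `O=C(Nc1cc(C(F)(F)F)cc(C(F)(F)F)c1)c1ccc(Br)cc1O` differs from compound 2 in one place: bromo in place of chloro on an aromatic carbon. Going by the values given here, no measured pair shows this same change, so its size is not known from the data. Starting from compound 2 at 200 nM, the step of no change at the digits printed from compound 2 to compound 4 (within the scatter) is expected to be small, with no direction beyond the scatter. Compound 4 is therefore estimated at 200 nM, within a range from 100 nM to 400 nM.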

Compound 4, half-maximal inhibitory concentration: 270 nM
Compound 4: the middle estimate sits 1.4-fold (0.13 log units) below what was measured, within the range that was stated.
By their numbers in this assay, from the lowest: compounds 2, 4, 3 and 1 (each within the scatter of the next, the first and the last beyond it).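

Going by these compounds alone, this is the only pair that differs in one place. In this assay the exchange of chloro for bromo, para to a large group and meta to a hydroxy group, gives a 1.4-fold higher number from compound 2 to compound 4 (0.13 log units; within the scatter) and so does not separate these two halogens at this position. No measurement shown explains this result.

From the compounds shown here alone, it remains open whether an amine, a methoxy group or a carboxylic acid at this position would keep the number in this range. Going by these compounds, the effect of a bromo group elsewhere on the core also remains open.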